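Dimethylamino for 4-hydroxypiperidin-1-yl, compound 2 to compound 3

A few compounds are considered here, and "the series" means these few. Any claim that something is new, unique, unknown or untested is made for them only; others in the source may bear on it.

In a functional assay with Oryctolagus cuniculus as the target (on this read-out lower numbers stand for stronger inhibition and higher numbers for weaker inhibition), compound 1 (`CN(C)Cc1ccccc1-c1ccc(N2CCc3c(C(F)(F)F)nn(-c4ccc5onc(N)c5c4)c3C2=O)c(F)c1`) gives 600 nM and compound 2 (`Nc1noc2ccc(-n3nc(C(F)(F)F)c4c3C(=O)N(c3ccc(-c5ccccc5CN5CCC(O)CC5)cc3)CC4)cc12`) gives 510 nM, so compound 2 stands within the scatter of compound 1. Compound 3 (`CN(C)Cc1ccccc1-c1ccc(N2CCc3c(C(F)(F)F)nn(-c4ccc5onc(N)c5c4)c3C2=O)cc1`) carries dimethylamino in place of 4-hydroxypiperidin-1-yl on a saturated chain carbon bound to an aromatic carbon. Among the measured compounds shown here, no measured step covers this change. With only the close values of compound 1 and compound 2 to go on, no shift beyond the scatter is expected in this assay. The estimated change is a 1.0-fold lower number from compound 2 to compound 3 (0.01 log units; within the scatter). The expected value for compound 3 is 500 nM, within a range of 200 nM to 1200 nM.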

Compound 3, half-maximal inhibitory concentration: 223 nM
Compound 3: middle estimate off by 2.2-fold (0.35 log units), on the high side; low and high end bracket the measured number.
By their numbers in this assay, from the lowest: compound 3; then compounds 2 and 1 (each within the scatter of the next).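

In this assay, dimethylamino in place of 4-hydroxypiperidin-1-yl on a saturated chain carbon bound to an aromatic carbon gives a 2.3-fold lower number from compound 2 to compound 3 (0.36 log units; beyond the scatter). Hydrogen in place of fluoro on an aromatic carbon gives a 2.7-fold lower number from compound 1 to compound 3 (0.43 log units; beyond the scatter). Each of these two places therefore moves the number beyond the scatter, which the close values of compound 1 and compound 2 alone did not show.

No data at hand account for either step. As far as these compounds go, what pyrrolidin-1-yl or morpholin-4-yl would give on that saturated chain carbon, or chloro on that aromatic carbon, stays open.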